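Working notes: replacing iodo in compound 1

The source may report more compounds than this note shows. Statements on the series, on what has been measured and on what is new or still open speak of the compounds shown alone.

Values in a functional assay on C6 cells (Rattus norvegicus) for inhibition, read by sulforhodamine B assay, with a stated time of 72 h; a lower number here means that less compound is needed, a higher number that more compound is needed for the effect:
- compound 1 `O=C(/C=C/c1ccc([N+](=O)[O-])o1)c1ccc(I)cc1`: 2100 nM
- compound 2 `CC(C)(C)c1ccc(C(=O)/C=C/c2ccc([N+](=O)[O-])o2)cc1`: 28600 nM
- compound 3 `O=C(/C=C/c1ccc([N+](=O)[O-])o1)c1ccc(-n2ccnc2)cc1`: not yet measured

Compound 1 has the lower of the two measured numbers in this assay. The next change is 1H-imidazol-1-yl in place of iodo on an aromatic carbon. For the measured compounds named here, the only measured step at this place is tert-butyl in place of iodo, a 14-fold higher number from compound 1 to compound 2 (1.13 log units; beyond the scatter), which is large and beyond the scatter. This single step involves a different group, so it shows that the place matters but does not fix the direction. A smaller step towards a higher number is expected in this assay. The estimated step is a 1.9-fold higher number from compound 1 to compound 3 (0.28 log units; within the scatter). For compound 3 the expected value is 4000 nM, with an estimated range of 900 nM to 18000 nM.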

Compound 3, half-maximal effective concentration: 3500 nM
The estimate for compound 3 lay 1.1-fold (0.06 log units) above the measured number; measured number inside the range.
By their numbers in this assay, from the lowest: compounds 1 and 3 (each within the scatter of the next); then compound 2.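

In this assay 1H-imidazol-1-yl can take the place of iodo without a step beyond the scatter (a 1.7-fold higher number from compound 1 to compound 3 (0.22 log units; within the scatter)), so the result with tert-butyl does not hold for every replacement of iodo. The choice of group at this place still matters, as 1H-imidazol-1-yl in place of tert-butyl shows (an 8.2-fold lower number from compound 2 to compound 3 (0.91 log units; beyond the scatter)). No available evidence accounts for the gap between these two groups.

As far as these compounds go, whether an amine, a carboxylic acid or a longer chain at this place would stay with compound 1 and compound 3 or fall with compound 2 remains open.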